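This account rests on a few compounds, and the source may have more. Where it says the series, first, only, none or still open, it means among the compounds named here.

Of the compounds shown here, three have been tested in an ADME assay on HepG2 cells (Homo sapiens) for cytotoxicity (on this read-out lower numbers stand for higher toxicity in this test and higher numbers for lower toxicity in this test), and none of them gave an exact number. Compound 1 `CCC[C@@H](/C=C/S(=O)(=O)c1ccccc1)NC(=O)c1cccc2cccnc12` gives only a limit, > 80000 nM. Compound 2 `CC1=CC(C)(C)Nc2c(C(=O)N[C@H](/C=C/S(=O)(=O)c3ccccc3)CCc3ccccc3)cccc21` also gives only a limit, > 300000 nM. Compound 3 `O=C(N[C@H](/C=C/S(=O)(=O)c1ccccc1)CCc1ccccc1)c1cccc2c1NCCC2` likewise gives only a limit, > 160000 nM. Compound 3 therefore has no exact place on the scale, and its limit cannot be ranked against the other two.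

Compound 4 `O=C(N[C@H](/C=C/S(=O)(=O)c1ccccc1)CCc1ccccc1)c1ccc([N+](=O)[O-])o1` has not yet been measured. It differs from compound 3 in one place: 5-nitrofuran-2-yl in place of 1,2,3,4-tetrahydroquinolin-8-yl on a carbonyl carbon. Put simply, this is 5-nitrofuran-2-yl in place of 1,2,3,4-tetrahydroquinolin-8-yl on a carbonyl carbon.

Going by the values given here, no measured pair of compounds differs in just one place, so the size of this change can only be judged, not read from the data. The swap replaces a large part of the molecule, and a moderate step downward in this assay, toward higher toxicity in this test, is expected rather than a change within the scatter. The expected change is an at least 2.6-fold lower number from compound 3 to compound 4 (0.42 log units; beyond the scatter). This test may well report only a limit again. For compound 4 the estimated value is 60000 nM, with an expected range from 15000 nM to 200000 nM.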

Compound 4, half-maximal cytotoxic concentration: 5170 nM
For compound 4 the middle estimate is 12-fold (1.06 log units) above the measured one; measured number outside the range, below it.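

The group on the carbonyl carbon turns out to matter a great deal in this assay: 5-nitrofuran-2-yl in place of 1,2,3,4-tetrahydroquinolin-8-yl gives an at least 30-fold lower number from compound 3 to compound 4 (1.49 log units; beyond the scatter). Going by these compounds alone, the earlier compounds gave limits only, so they could not show that any change reaches a measurable toxicity in this test, whereas compound 4 supplies the first exact number on the scale. The step starts from a limit, so its true size may be larger than the printed figure: the limit of > 160000 nM in this assay, at which 1 of the 4 values shown sits.

The swap changes the ring and adds a nitro group in a single move, so the compounds shown cannot say which of the two carries the drop, and a plain furan-2-yl, or a furan ring with a nitrile or a carboxylic acid in place of the nitro group, would separate those two parts. Whether 5-nitrofuran-2-yl has a similar effect with the propyl chain and the other side of compound 1 also stays open, as does any reason for the drop, which these values alone do not give.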